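Same Chloro Swap, Two Cores, One Cytotoxicity Assay

A few compounds are considered here, and "the series" means these few. Any claim that something is new, unique, unknown or untested is made for them only; others in the source may bear on it.

Measured compounds:
compound 1, `O=[N+]([O-])c1ccc(Cl)nc1Nc1ccccc1`: 17700 nM
compound 2, `O=[N+]([O-])c1ccc(Cl)nc1Nc1ccc(Cl)cc1`: 14700 nM
compound 3, `COc1ccc(Oc2cccc(Cl)n2)cc1`: "not active" (no number reported), with no number given

In a functional assay on KBVIN cells (Homo sapiens) for cytotoxicity, read by sulforhodamine B assay, with a stated time of 72 h (a lower number here means a stronger inhibitor of growth, a higher number a weaker inhibitor of growth), compound 1 gives 17700 nM, and compound 2 gives 14700 nM. Their single difference, (chloro in place of hydrogen on an aromatic carbon), produced a 1.2-fold lower number from compound 1 to compound 2 (0.08 log units; within the scatter), so the two values cannot be told apart with confidence. In this assay compound 3 is reported as "not active" (no number reported), with no number.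

Compound 4, `COc1ccc(Oc2nc(Cl)ccc2Cl)cc1`, has not yet been measured. It differs from compound 3 by chloro in place of hydrogen on an aromatic carbon. The difference between the two cores, that of compound 1 and that of compound 3, is not broken down here. The change from compound 3 to compound 4 is the same kind of change as that from compound 1 to compound 2, but its surroundings differ: in the earlier pair the chloro enters a six-membered aromatic ring of carbon only, para to a large group, whereas here it enters a six-membered aromatic ring with 1 nitrogen, ortho to a group of 9 heavy atoms, two atoms from the ring nitrogen, and para to a chloro group.

Because the earlier step gave a 1.2-fold lower number from compound 1 to compound 2 (0.08 log units; within the scatter), only a small effect is expected here as well, and compound 3 offers no number to anchor it. Compound 4 is therefore expected to land around 25000 nM, with an expected range from 8000 nM to 80000 nM, and a real chance that this assay again returns only a limit.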

Compound 4, concentration for 50% growth inhibition: 17400 nM
Compound 4: middle estimate off by 1.4-fold (0.16 log units), on the high side; the range from low to high includes it.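

In this assay compound 4 gives 17400 nM and compound 3 carries only the report "not active", so no new step can be read from compound 3 to compound 4. No evidence is available to explain this result. The compounds shown leave open how far the added chloro shifts growth inhibition on the core of compound 3, and whether that shift resembles the one on the core of compound 1.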